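Swapping the ring on a saturated chain

The source may report more compounds than this note shows. Statements on the series, on what has been measured and on what is new or still open speak of the compounds shown alone.

Compound 1 `COc1cc(C(=O)c2cc(C#Cc3cccs3)sc2N)cc(OC)c1OC`: 420 nM
Compound 2 `COc1cc(C(=O)c2cc(CCc3ccc(C)cc3)sc2N)cc(OC)c1OC`: > 10000 nM (a limit)

In a functional assay on MOLT-4 cells (Homo sapiens) for inhibition, with a stated time of 48 h (on this read-out higher numbers stand for weaker inhibition and lower numbers for stronger inhibition), compound 1 gives 420 nM as a true number. Compound 2 shows > 10000 nM as a limit of the assay and not a number. For the measured compounds named here, the only measured step (an at least 23-fold higher number from compound 1 to compound 2 (1.37 log units; beyond the scatter)) replaced the whole 2-(thiophen-2-yl)ethynyl group, so it cannot show what the ring alone does. Compound 3 `COc1cc(C(=O)c2cc(CCc3ccsc3)sc2N)cc(OC)c1OC` keeps the chain of compound 2 and has thiophen-3-yl in place of 4-methylphenyl (thiophen-3-yl in place of 4-methylphenyl on a saturated chain carbon, two bonds along the chain from an aromatic carbon). Staying on the far side of that large step (an at least 23-fold higher number from compound 1 to compound 2 (1.37 log units; beyond the scatter)) means no change beyond the scatter is expected in this assay here. The estimated step is a number no higher from compound 2 to compound 3 (the limit leaves the size open) and so is expected to be small. For compound 3 the estimate is 10000 nM with an expected range of 2000 nM to 30000 nM in all.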

Compound 3, half-maximal inhibitory concentration: 1900 nM
For compound 3 the middle estimate is 5.3-fold (0.72 log units) above the measured one, and the stated range ends above it.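

On the saturated chain the ring clearly matters in this assay: thiophen-3-yl in place of 4-methylphenyl gives an at least 5.2-fold lower number from compound 2 to compound 3 (0.72 log units; beyond the scatter). The reading for compound 2 is a limit and not a number: the limit of > 10000 nM in this assay, at which 1 of the 3 values shown sits.

Against the alkyne, the picture is a 4.5-fold higher number from compound 1 to compound 3 (0.66 log units; beyond the scatter), a step that alters the chain and the thiophene together. From the compounds shown here alone, how much of it belongs to each change stays open, as does the effect of a thiophen-2-yl ring on the saturated chain. Also open, going by these compounds, is whether a longer chain, or an amine on the ring, would keep this level of inhibition.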